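Methyl on the five-membered ring: compound 4 against compound 1

The source may hold more compounds than are shown below. What is called first, only, known or untested is meant among the compounds shown, and "the series" means these compounds.

Compound 1 `COc1cc(/C(Cl)=C/C=C(\C#N)C(=O)c2c[nH]c3ccccc23)cc(OC)c1OC` gives 4000 nM in a functional assay on MCF7 cells (Homo sapiens) for cytotoxicity, read by sulforhodamine B assay, with a stated time of 48 h (a lower number here means a stronger inhibitor of growth, a higher number a weaker inhibitor of growth), the lowest of the three numbers recorded. Compound 3 `COc1ccc(/C(Cl)=C/C=C(\C#N)C(=O)c2c[nH]c3ccccc23)cc1OC` gives 44200 nM in this assay, and compound 2 `COc1ccc(/C(Cl)=C/C=C(\C#N)C(=O)c2c[nH]c3ccc(Br)cc23)cc1` gives 80300 nM in this assay. For the measured compounds named here, the only single-point step measured, an 11-fold higher number from compound 1 to compound 3 (1.04 log units; beyond the scatter), concerns a methoxy group elsewhere in the molecule; no measured step touches the five-membered aromatic ring. Compound 4 `COc1cc(/C(Cl)=C/C=C(\C#N)C(=O)c2c(C)[nH]c3ccccc23)cc(OC)c1OC` differs from compound 1 by methyl in place of hydrogen on an aromatic carbon, read one bond further out as 1H-indol-3-yl to 2-methyl-1H-indol-3-yl. Nothing measured bears on this change, so in this assay no step beyond the scatter is expected, no change at the digits printed from compound 1 to compound 4 (within the scatter). For compound 4 the estimate in this assay is 4000 nM, with a range from 1300 nM to 12000 nM.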

Compound 4, concentration for 50% growth inhibition: < 100 nM
Compound 4 was reported as a limit (the forecaster's own chance of this, stated with the estimate: 3%); middle value at least 40-fold (1.60 log units) away from the limit.
By their numbers in this assay, from the lowest: compound 1; then compounds 3 and 2 (each within the scatter of the next). At a limit, below all of these: compound 4.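

In this assay, methyl in place of hydrogen on an aromatic carbon of the five-membered aromatic ring gives an at least 40-fold lower number from compound 1 to compound 4 (1.60 log units; beyond the scatter). For the compounds shown here, this is the first measured step at this position, and it shows that a single added carbon here produces a large step. Compound 4 is reported as a limit, so the size of the step is only a bound: the limit of < 100 nM in this assay, at which 1 of the 4 values shown sits.

On these data alone, whether an ethyl group, a longer chain or an amine at this position would give a similar step remains open. Also open, as far as these compounds go, is whether the same methyl would have this effect on compound 2 or compound 3.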